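This account rests on a few compounds, and the source may have more. Where it says the series, first, only, none or still open, it means among the compounds named here.

Measured compounds in a physicochemical assay for solubility, in simulated intestinal fluid, with a stated time of 4 h; a lower number here means a less soluble compound, a higher number a more soluble compound: compound 1 `N#Cc1ccc(O[C@H]2CN(S(=O)(=O)c3ccc(Cl)cc3)C[C@@]2(O)CO)cc1F` gives 44 ug/mL; compound 2 `N#Cc1ccc(O[C@H]2CN(S(=O)(=O)c3ccc(C(F)(F)F)cc3)C[C@@]2(O)CO)cc1F` gives 5 ug/mL; compound 3 `N#Cc1ccc(O[C@H]2CN(S(=O)(=O)c3ccc(C(F)(F)F)nc3)C[C@@]2(O)CO)cc1F` gives 98 ug/mL.

Compound 3 stands highest of the three, with compound 1 nearest and compound 2 furthest behind. Compound 4 `N#Cc1ccc(O[C@H]2CN(S(=O)(=O)c3ccc(Cl)cn3)C[C@@]2(O)CO)cc1F` differs from compound 3 in one place: 5-chloropyridin-2-yl in place of 6-(trifluoromethyl)pyridin-3-yl on a sulfonyl sulfur. Within the data shown here, two measured steps bear on this. Swapping chloro for trifluoromethyl gave an 8.8-fold lower number from compound 1 to compound 2 (0.94 log units; beyond the scatter), so the reverse exchange points upward. Moving from a benzene ring to a pyridine ring gave a 20-fold higher number from compound 2 to compound 3 (1.29 log units; beyond the scatter) and a 2.2-fold higher number from compound 1 to compound 3 (0.35 log units; beyond the scatter), and compound 4 keeps the pyridine ring. As far as these compounds go, a modest upward step is therefore expected in this assay, though the changed attachment point is untested, so the estimate for compound 4 is 160 ug/mL (range 55 ug/mL to 450 ug/mL), meaning an expected step of a 1.6-fold higher number from compound 3 to compound 4 (0.21 log units; within the scatter).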

Compound 4, solubility: 26 ug/mL
Compound 4: middle estimate off by 6.2-fold (0.79 log units), on the high side; measured number below the stated range.
By their numbers in this assay, from the lowest: compound 2; then compounds 4 and 1 (each within the scatter of the next); then compound 3.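

In this assay, a pyridine ring on the sulfonyl sulfur does not by itself secure a high number: 5-chloropyridin-2-yl in place of 6-(trifluoromethyl)pyridin-3-yl gave a 3.8-fold lower number from compound 3 to compound 4 (0.58 log units; beyond the scatter). The same group still gave a 5.2-fold higher number from compound 2 to compound 4 (0.72 log units; beyond the scatter), while replacing 4-chlorophenyl with it gave a 1.7-fold lower number from compound 1 to compound 4 (0.23 log units; within the scatter). No measurement shown here explains these steps.

As far as these compounds go, compound 4 changes both the substituent and the ring's attachment point, so their separate contributions remain open. From the compounds shown here alone, how an amine or a methoxy group on this pyridine ring would behave also remains open.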